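A few compounds are considered here, and "the series" means these few. Any claim that something is new, unique, unknown or untested is made for them only; others in the source may bear on it.

Compound 2, with the structure `CCCc1ccc(-c2ccc(N(C[C@@H](N)[C@@H](C)CC)C(=O)[C@@H]3C[C@H]3c3ccccc3)cc2)cc1`, gives 61 nM in a functional assay for agonist activity at G protein-coupled receptor 88 (Homo sapiens), read by HTRF and cAMP accumulation; on this read-out higher numbers stand for an effect only at larger amounts of compound and lower numbers for an effect already at smaller amounts. For the measured compounds named here, of the two compounds measured, compound 2 holds the lowest number; its only neighbour, compound 1, with the structure `CC[C@H](C)[C@H](N)CN(C(=O)[C@@H]1C[C@H]1c1c(F)cccc1F)c1ccc(-c2ccccc2)cc1`, gives 11000 nM in this assay, a gap that lies well beyond the usual scatter. Going by the values given here, compound 1 and compound 2 differ in more than one place, so no single step between them can be read from their numbers alone.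

Compound 3, with the structure `CC[C@H](C)[C@H](N)CN(C(=O)[C@@H]1C[C@H]1c1ccccc1)c1ccc(-c2ccc(CNC)cc2)cc1`, is the next compound and has not yet been measured. It differs from compound 2 in one place: methylamino in place of ethyl on a saturated chain carbon bound to an aromatic carbon. A propyl group thus becomes a (methylamino)methyl group, bringing one hydrogen-bond donor and one hydrogen-bond acceptor where there were none.

Among the compounds with values here, with no measured pair showing this change, the expectation for compound 3 rests on compound 2 alone. A moderate loss is expected, a step of a 4.1-fold higher number from compound 2 to compound 3 (0.61 log units; beyond the scatter) toward higher numbers, somewhat beyond the scatter but not a large one. Compound 3 is therefore estimated at 250 nM, within a range from 60 nM to 1500 nM.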

Compound 3, half-maximal effective concentration: 6400 nM
The estimate for compound 3 lay 26-fold (1.41 log units) below the measured number, and the stated range ends below it.
By their numbers in this assay, from the lowest: compound 2; then compounds 3 and 1 (each within the scatter of the next).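

Going from 4-propylphenyl to 4-((methylamino)methyl)phenyl gives a 100-fold higher number from compound 2 to compound 3 (2.02 log units; beyond the scatter) in this assay, and this is the first single change in the series whose effect can be read. It shows that this position, a saturated chain carbon bound to an aromatic carbon, is far from indifferent to what it carries: the exchange of ethyl for methylamino leaves the count of heavy atoms unchanged, puts one nitrogen in place of one carbon and adds one hydrogen-bond donor and one hydrogen-bond acceptor, and nothing else separates compound 2 from compound 3. Nothing at hand explains why the number moves so far.

This one pair leaves open whether the step follows from the nitrogen itself or from where it stands in the chain, and whether a methoxymethyl group, an aminomethyl group, a dimethylaminomethyl group or a longer chain such as butyl would fall closer to compound 2 or to compound 3. It also leaves open whether the same exchange would bring a step of like size on a core carrying other groups, such as the fluorine-bearing phenyl of compound 1.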